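Vinyl in Place of Heptyl at the End of an Ester Chain

The source may report more compounds than this note shows. Statements on the series, on what has been measured and on what is new or still open speak of the compounds shown alone.

Compound 1 `CCCCCCCCCCCCCCCC(=O)O[C@H]1[C@H](O)[C@H](n2ccc(N)nc2=O)O[C@@H]1CO` gives 0.24 ug/mL in a functional assay on HeLa cells (Homo sapiens) for cytotoxicity, read by cell counting, with a stated time of 48 h; on this read-out higher numbers stand for an effect only at larger amounts of compound and lower numbers for an effect already at smaller amounts.
Compound 2 `CCCCCCCCCCCC(=O)OC[C@H]1O[C@@H](n2ccc(N)nc2=O)[C@@H](O)[C@@H]1OC(=O)CCCCCCCCCCC` gives 0.5 ug/mL in this assay.
Compound 3 `CCCC(=O)OC[C@H]1O[C@@H](n2ccc(N)nc2=O)[C@@H](O)[C@@H]1OC(=O)CCC` gives 0.11 ug/mL in this assay.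

Among these three, compound 1 stands second highest: compound 2 sits above it and compound 3 below it, both beyond the scatter. Going by the values given here, no single-change pairs exist among the measured compounds, and the three ester patterns differ in several places at once, so no step size can be read off. Compound 4 `C=CCCCCCCCCC(=O)O[C@H]1[C@H](O)[C@H](n2ccc(N)nc2=O)O[C@@H]1CO` differs from compound 1 by vinyl in place of heptyl on a saturated chain carbon, eight bonds along the chain from a carbonyl carbon. Since chain length shows no consistent link to the read-out across compounds 1, 2 and 3, the expected step in this assay is small, with no clear direction. Compound 4 is therefore estimated at 0.3 ug/mL, between 0.1 ug/mL and 0.9 ug/mL, a change of a 1.3-fold higher number from compound 1 to compound 4 (0.10 log units; within the scatter).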

Compound 4, concentration for half-maximal effect: 0.05 ug/mL
Beside the measured number, compound 4's estimate is 6.0-fold (0.78 log units) above it; measured number outside the range, below it.
By their numbers in this assay, from the lowest: compound 4; then compound 3; then compound 1; then compound 2.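

In this assay, vinyl in place of heptyl on a saturated chain carbon, eight bonds along the chain from a carbonyl carbon, gives a 4.8-fold lower number from compound 1 to compound 4 (0.68 log units; beyond the scatter) and the step lies beyond the scatter. This is the only single-change step among the compounds shown, and it shows that the read-out responds to what stands at the end of this ester chain. No measurement shown accounts for the step. From the compounds shown here alone, the change shortens the chain and adds a double bond at once, so the share of each remains open. An ethyl group at the same place would separate the two.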